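A few compounds are considered here, and "the series" means these few. Any claim that something is new, unique, unknown or untested is made for them only; others in the source may bear on it.

Compound 1 `CCN(CC)CCCOc1cc2ncnc(Nc3nc4ccc(C(=O)Nc5c(C)cccc5C)cc4s3)c2cc1OC` is the starting point; in a functional assay on K562 cells (Homo sapiens) for cytotoxicity, read by WST assay, with a stated time of 72 h (on this read-out lower numbers stand for stronger inhibition and higher numbers for weaker inhibition), compound 1 gives 28400 nM. Compound 2 `CCN(CC)CCCOc1cc2ncnc(Nc3nc4ccc(C(=O)Nc5c(C)cccc5Cl)cc4s3)c2cc1OC` differs from it at one aromatic carbon, and in this assay compound 2 gives 9600 nM. That change brought a 3.0-fold lower number from compound 1 to compound 2 (0.47 log units; beyond the scatter). Among the two numbers measured so far, compound 2 stands at the lowest, with compound 1 as the only neighbour.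

Compound 3 `COc1cc2c(Nc3nc4ccc(C(=O)Nc5c(C)cccc5Cl)cc4s3)ncnc2cc1OCCCN1CCC(C)CC1` keeps the chloro-bearing amide of compound 2 and changes the chain end: 4-methylpiperidin-1-yl in place of diethylamino on a saturated chain carbon, three bonds along the chain from an oxygen on an aromatic ring. Going by the values given here, no measured step touches this part of the molecule; the only step available concerns the aromatic carbon far from the chain, so it gives no guidance here. With the entering group and the leaving group each carrying one hydrogen-bond acceptor and no charge, a step within the usual scatter is expected, in no particular direction, and the estimated step is a 1.1-fold lower number from compound 2 to compound 3 (0.03 log units; within the scatter). The estimated value of compound 3 in this assay is therefore 9000 nM, with a range from 3500 nM to 25000 nM.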

Compound 3, half-maximal inhibitory concentration: 8300 nM
Compound 3: the middle estimate sits 1.1-fold (0.04 log units) above what was measured; the range from low to high includes it.
By their numbers in this assay, from the lowest: compounds 3 and 2 (each within the scatter of the next); then compound 1.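

In this assay, 4-methylpiperidin-1-yl in place of diethylamino gives a 1.2-fold lower number from compound 2 to compound 3 (0.06 log units; within the scatter), so this read-out does not separate the two chain ends. Going by these compounds alone, this is the first measured change at the chain end, as the earlier step concerned a different place, an aromatic carbon: here a six-membered non-aromatic ring with 7 heavy atoms stands in for an open group with 5, with no difference that can be read. Nothing measured here speaks to why the two compounds sit so close.

The compounds shown leave open whether a chain end with a second ring nitrogen, such as 4-methylpiperazin-1-yl, or with a ring oxygen, such as morpholin-4-yl, or a longer chain would read the same. Nor do they tell whether the step from methyl to chloro would keep its size with 4-methylpiperidin-1-yl at the chain end.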